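Quaternary Ammonium Headgroup Exchange at the Chain Terminus

The source may report more compounds than this note shows. Statements on the series, on what has been measured and on what is new or still open speak of the compounds shown alone.

Three compounds sharing one core were tested in an assay on LX2 cells for inhibition of COL1A1 promoter (Homo sapiens), read by a luciferase reporter, with a stated time of 24 h, tested at 20 uM; a lower number here means a weaker effect, a higher number a stronger effect of the compound at the concentration tested. Compound 1 `Cc1cc(OCCCCCCC[N+]23CCN(CC2)CC3)ccc1-n1cc(C(=O)Nc2cc(F)cc(F)c2)c(=O)c2ccc(N(C)C)nc21` was reported as "not active" (no number reported), with no number given. Compound 3 `CC[N+]1(CCCCCCCOc2ccc(-n3cc(C(=O)Nc4cc(F)cc(F)c4)c(=O)c4ccc(N(C)C)nc43)c(Cl)c2)CCCCC1` was likewise reported as "not active" (no number reported), again without a number. Among the measured compounds shown here, compound 2 `Cc1cc(OCCCCCCC[N+]2(C)CCCC2)cc(-n2cc(C(=O)Nc3cc(F)cc(F)c3)c(=O)c3ccc(N(C)C)nc32)c1` is the only compound for which a figure exists: in this assay compound 2 gives 4.32%, a read-out that sits within the scatter of a null effect at the concentration tested. Compound 2 therefore stands as the sole numerical anchor, and it stands close to no effect.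

Compound 4 `Cc1cc(OCCCCCCC[N+]2(C)CCN(C)CC2)cc(-n2cc(C(=O)Nc3cc(F)cc(F)c3)c(=O)c3ccc(N(C)C)nc32)c1` differs from compound 2 in one place: a group of 8 heavy atoms (6 carbon, 2 nitrogen; one six-membered non-aromatic ring with 2 hetero atoms) in place of a group of 6 heavy atoms (5 carbon, 1 nitrogen; one five-membered non-aromatic ring with 1 hetero atom), on a saturated chain carbon, seven bonds along the chain from an oxygen on an aromatic ring. Nothing measured in this series shows a charged chain-terminal headgroup of any kind producing an inhibition beyond the scatter, so the change offers no measured ground for a shift in either direction.

On this basis the step is expected to be a number 0.7 percentage points higher from compound 2 to compound 4 (within the scatter), a size that lies within the usual scatter. Compound 4 is accordingly estimated to give 5% in this assay, with a plausible range from -8% to 18%, and a real chance that it is returned simply as not active.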

Compound 4, a percentage reported as inhibition, at one concentration (the size of the read-out at that concentration, not a potency): 2.8%
The estimate for compound 4 lay 2.2 percentage points above the measured number; low and high end bracket the measured number.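

The exchange gives the series its first step between two reported numbers. In this assay the change reads a number 1.5 percentage points lower from compound 2 to compound 4 (within the scatter) and so does not separate the six-membered non-aromatic ring with 2 hetero atoms from the five-membered non-aromatic ring with 1 hetero atom, on a saturated chain carbon, seven bonds along the chain from an oxygen on an aromatic ring. The entering group carries 1 hydrogen-bond acceptor where the leaving group has 0, at the same net charge of +1, and the two compounds still read within the scatter of each other, while no measurement shown here bears on why they read alike.

The compounds shown leave open whether a primary amine or a carboxylic acid in place of these charged groups, or a longer chain carrying them, would give an inhibition beyond the scatter. From the compounds shown here alone, it also remains open whether a morpholine ring at the same place would read any differently from compound 4 in this assay when tested under the same conditions.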